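The source may report more compounds than this note shows. Statements on the series, on what has been measured and on what is new or still open speak of the compounds shown alone.

Measured compounds:
compound 1 `O=C(Nc1cccc(-n2cc(-c3ccncc3)c(-c3ccc(Cl)c(O)c3)n2)c1)Nc1ccc(Cl)c(Cl)c1`: 8100 nM
compound 2 `COc1cc(-c2nn(-c3cccc(NC(=O)c4ccc(Cl)c(C(F)(F)F)c4)c3)cc2-c2ccncc2)ccc1Cl`: 19700 nM
compound 3 `COc1cc(-c2nn(-c3cccc(NC(=O)Nc4cccc(C(F)(F)F)c4)c3)cc2-c2ccncc2)ccc1Cl`: 2410 nM

In a functional assay on Malme-3M cells (Homo sapiens) for inhibition, read by sulforhodamine B assay, with a stated time of 48 h (on this read-out higher numbers stand for weaker inhibition of growth and lower numbers for stronger inhibition of growth), compound 1 stands second highest of the three numbers; compound 2 gives a higher number and compound 3 a lower one, both differences lying beyond the scatter. Compound 4 `O=C(Nc1cccc(-n2cc(-c3ccncc3)c(-c3ccc(Cl)c(O)c3)n2)c1)Nc1ccc(Cl)c(C(F)(F)F)c1` is the unmeasured member. Its change from compound 1 is trifluoromethyl in place of chloro on an aromatic carbon. Among the compounds with values here, no measured step shows this change: the one step on record, an 8.2-fold lower number from compound 2 to compound 3 (0.91 log units; beyond the scatter), alters the group on the carbonyl carbon, and the 4-chloro-3-(trifluoromethyl)phenyl group appears in compound 2 only within an amide, so it offers no direct read on a urea. With nothing to point either way, the step is expected to stay within the scatter, a 1.2-fold lower number from compound 1 to compound 4 (0.06 log units; within the scatter). Compound 4 is thus estimated at 7000 nM, in a range from 3000 nM to 20000 nM.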

Compound 4, concentration for total growth inhibition: 1650 nM
Compound 4: middle estimate off by 4.2-fold (0.63 log units), on the high side; the measured number lies below the stated range.
By their numbers in this assay, from the lowest: compounds 4 and 3 (each within the scatter of the next); then compound 1; then compound 2.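

In this assay, within the data shown here, a 4.9-fold lower number from compound 1 to compound 4 (0.69 log units; beyond the scatter) is the first measured read on this position, with 3,4-dichlorophenyl on the urea becoming 4-chloro-3-(trifluoromethyl)phenyl. It shows that, on this urea, the position ortho to the remaining chloro group does not treat trifluoromethyl and chloro alike, with the change favouring stronger inhibition of growth. Nothing available accounts for this step. The compounds shown leave open how a nitrile, an amine or a methyl group would behave at this position. They also leave open whether the same change would give a similar step on another urea.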